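Amide tail variation on the shared pyrazolylpyridine anilide core

This account rests on a few compounds, and the source may have more. Where it says the series, first, only, none or still open, it means among the compounds named here.

Of the compounds shown here, two have numbers so far. Compound 1 `Cc1ccc(NC(=O)c2cccc(Cl)c2)cc1-n1cc(-c2cccnc2)cn1` gives 1320 nM in a functional assay on K562 cells (Homo sapiens) for inhibition, read by MTT assay, with a stated time of 48 h; a higher number here means a weaker inhibitor, a lower number a stronger inhibitor. Compound 2 `Cc1ccc(NC(=O)c2ccc(C(F)(F)F)cc2)cc1-n1cc(-c2cccnc2)cn1` gives 760 nM in this assay. For the measured compounds named here, the only single-point step between them, a 1.7-fold lower number from compound 1 to compound 2 (0.24 log units; within the scatter), exchanges the aryl group on the carbonyl carbon and lies within the scatter. Compound 2 therefore holds the lowest of the two numbers, with compound 1 as its nearest neighbour, a gap that the scatter covers.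

Compound 3 `Cc1ccc(NC(=O)c2ccc(CN3CCCN(C)CC3)cc2)cc1-n1cc(-c2cccnc2)cn1` carries the change ((4-methyl-1,4-diazepan-1-yl)methyl in place of trifluoromethyl on an aromatic carbon); the new group sits on an aromatic carbon of a six-membered aromatic ring of carbon only, para to a large group. Going by the values given here, no measured step involves an entering group of this kind or a seven-membered non-aromatic ring with two hetero atoms, so nothing speaks to the size or direction of the step. Among the compounds with values here, the one measured step, from compound 1 to compound 2, shows that changing the aryl on the carbonyl carbon moved the number only within the scatter. The estimate for compound 3 rests on the value of compound 2 and is expected to be 400 nM, within 100 nM to 1600 nM in this assay. That expectation corresponds to a step of a 1.9-fold lower number from compound 2 to compound 3 (0.28 log units; within the scatter), the direction being uncertain.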

Compound 3, half-maximal inhibitory concentration: 8650 nM
Compound 3: middle estimate off by 22-fold (1.33 log units), on the low side; measured number above the stated range.
By their numbers in this assay, from the lowest: compounds 2 and 1 (each within the scatter of the next); then compound 3.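

The aryl tail on the carbonyl carbon is not as indifferent to change as the first pair suggested. In this assay, for the compounds shown here, placing (4-methyl-1,4-diazepan-1-yl)methyl instead of trifluoromethyl on the aromatic carbon, para to a large group, gives an 11-fold higher number from compound 2 to compound 3 (1.06 log units; beyond the scatter), the first step beyond the scatter, so the number does respond to the group at this position, and here the larger entering group goes with the weaker result. Nothing at hand explains this step, and the change of group size, the seven-membered non-aromatic ring and its 2 hetero atoms cannot be separated from one another.

The compounds shown leave open whether the rise belongs to the seven-membered ring itself or to any amine carried on a methyl link at this position, which a piperazine, a morpholine or a plain dimethylamino group in the same place would help to settle. Also open, going by these compounds, is how a small neutral group such as methoxy or a chlorine atom would compare with trifluoromethyl here.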